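The source may report more compounds than this note shows. Statements on the series, on what has been measured and on what is new or still open speak of the compounds shown alone.

Measured in a functional assay on the whole organism with Canis familiaris (Canis lupus familiaris) as the target; a higher number here means that more compound is needed for the effect, a lower number that less compound is needed:
- compound 1 `Cc1ccccc1-c1nc2cc[nH]cc-2n1`: 2.2 mg/kg
- compound 2 `Cc1ccc(-c2nc3cc[nH]cc-3n2)c(C)c1`: 1.4 mg/kg
- compound 3 `COc1ccc(-c2nc3cc[nH]cc-3n2)cc1OC`: 0.4 mg/kg

In this assay, compound 2 at 1.4 mg/kg lies within the scatter of compound 1, while compound 3 at 0.4 mg/kg shows a clearly lower number than either.

The next structure is compound 4 `COc1cc(C)ccc1-c1nc2cc[nH]cc-2n1`. It differs from compound 2 in one place: methoxy in place of methyl on an aromatic carbon. This is methoxy in place of methyl on an aromatic carbon, ortho to a group of 9 heavy atoms and meta to a methyl group.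

Within the data shown here, only one measured step bears on this directly, and it is an indirect guide: a 1.6-fold lower number from compound 1 to compound 2 (0.20 log units; within the scatter). That step adds a methyl and says nothing about methoxy. Among the measured compounds shown here, the only measured compound with methoxy groups is compound 3 at 0.4 mg/kg, but it differs from compound 2 in more than one place and has no methyl group, so it suggests a direction and no more. A modest move towards a lower number is therefore expected, close to the edge of the scatter, and the expected step is a 2.0-fold lower number from compound 2 to compound 4 (0.30 log units; within the scatter). For compound 4 the estimated value in this assay is 0.7 mg/kg, with an expected range from 0.25 mg/kg to 2 mg/kg.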

Compound 4, dose for half-maximal effect: 0.28 mg/kg
Estimate against measurement, compound 4: 2.5-fold (0.40 log units) above, and the stated range covers the measured number.
By their numbers in this assay, from the lowest: compounds 4 and 3 (each within the scatter of the next); then compounds 2 and 1 (each within the scatter of the next).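

In this assay, the position ortho to a group of 9 heavy atoms and meta to a methyl group responds clearly to the exchange of methyl for methoxy, with a 5.0-fold lower number from compound 2 to compound 4 (0.70 log units; beyond the scatter). Among these compounds, the only earlier single-place step, a 1.6-fold lower number from compound 1 to compound 2 (0.20 log units; within the scatter), stayed within the scatter, so this is the first change in one place that moves the number beyond it, and it shows that the group held at this position matters for the dose needed in the whole animal. Nothing measured here accounts for the size of this step.

The compounds shown leave open whether the same exchange would have a comparable effect without the methyl group that compound 2 and compound 4 both carry at the position meta to the change. They also leave open whether the effect is specific to methoxy or would extend to other groups at this position, such as ethoxy, hydroxyl or an amine, which would show how much of the step depends on the oxygen and how much on the length of the chain.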